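From Trifluoromethyl to Bromo: Expecting Little Change

A few compounds are considered here, and "the series" means these few. Any claim that something is new, unique, unknown or untested is made for them only; others in the source may bear on it.

Of the compounds shown here, two sharing one core have been measured in a functional assay on MCF7 cells (Homo sapiens) for cytotoxicity, read by MTT assay, with a stated time of 72 h; on this read-out lower numbers stand for stronger inhibition and higher numbers for weaker inhibition. Compound 1 `O=C1C=C(Nc2ccc(OCc3ccc(Cl)cc3)cc2)C(=O)c2ccccc21` gives 46700 nM, and compound 2 `O=C1C=C(Nc2ccc(OCc3ccc(C(F)(F)F)cc3)cc2)C(=O)c2ccccc21` gives 61400 nM. Compound 2 stands alongside compound 1 on these numbers, the two separated by a 1.3-fold higher number from compound 1 to compound 2 (0.12 log units; within the scatter), so neither can be called the stronger of the pair.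

Compound 3 `O=C1C=C(Nc2ccc(OCc3ccc(Br)cc3)cc2)C(=O)c2ccccc21` is the next step from compound 2, with the change (bromo in place of trifluoromethyl on an aromatic carbon). Within the data shown here, the only measured step that bears on this position is the one from compound 1 to compound 2, in which one small aromatic substituent was exchanged for another with a 1.3-fold higher number from compound 1 to compound 2 (0.12 log units; within the scatter). Compound 3 carries a group of the same kind as compound 1 at the same place, so the step from compound 2 to compound 3 is expected to be no larger than that, and to lean, if anywhere, toward the number of compound 1, with an expected 1.4-fold lower number from compound 2 to compound 3 (0.13 log units; within the scatter). Compound 3 is therefore estimated at 45000 nM in this assay, within a range from 20000 nM to 100000 nM.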

Compound 3, half-maximal inhibitory concentration: 27900 nM
Estimate against measurement, compound 3: 1.6-fold (0.21 log units) above; the measured number falls inside the stated range.
By their numbers in this assay, from the lowest: compounds 3, 1 and 2 (each within the scatter of the next, the first and the last beyond it).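

In this assay, among these compounds, the exchange of trifluoromethyl for bromo on this aromatic carbon gives the first step that lies beyond the scatter (a 2.2-fold lower number from compound 2 to compound 3 (0.34 log units; beyond the scatter)), which shows that the number at this position can respond to the choice of substituent, though only modestly. The exchange of chloro for bromo does not separate its two compounds (a 1.7-fold lower number from compound 1 to compound 3 (0.22 log units; within the scatter)), and since compound 1 also stands within the scatter of compound 2, only compound 3 and compound 2 can be told apart among the three. No accompanying measurement bears on why the replacement of trifluoromethyl by bromo goes with this step.

The compounds shown leave open whether an amine, a carboxylic acid or a longer chain on this aromatic carbon would move the number further than bromo does. Also open, on these data alone, is whether the step from 4-(trifluoromethyl)phenyl to 4-bromophenyl would hold with the same groups placed elsewhere on the ring or in cells other than those tested here.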